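Swapping an Aryl Arm for a Dialkylamine Chain

The source may hold more compounds than are shown below. What is called first, only, known or untested is meant among the compounds shown, and "the series" means these compounds.

Compound 3 `Brc1cccc(Cn2ccc3nc(-c4ccccc4)nc-3c2)c1` is the only one of the three measured compounds that gives a number in an ADME assay on MDBK cells (Bos taurus) for cytotoxicity (a higher number here means that more compound is tolerated, a lower number that less compound is tolerated), where compound 3 gives 85000 nM. Compound 1 `Clc1cccc(Cn2ccc3nc(-c4ccccc4)nc-3c2)c1` reaches only a limit of the assay, giving > 100000 nM. Compound 2 `Clc1ccc(Cn2ccc3nc(-c4ccccc4)nc-3c2)cc1` likewise sits at a limit, with > 100000 nM. Compound 4 `CC(C)N(CCn1ccc2nc(-c3ccccc3)nc-2c1)C(C)C` differs from compound 3 in one place: (diisopropylamino)methyl in place of 3-bromophenyl on a saturated chain carbon bound to an aromatic nitrogen. The two measured steps at that same place are a step that the two limits leave unreadable from compound 1 to compound 2 and an at least 1.1-fold lower number from compound 2 to compound 3 (0.07 log units; that floor lies within the scatter); neither is readable as beyond the scatter because the limit of > 100000 nM in this assay, at which 2 of the 3 values shown sit, caps two of the three values. With no readable step at this place, for compound 4 a step of a 1.2-fold higher number from compound 3 to compound 4 (0.07 log units; within the scatter) is expected. Compound 4 is therefore estimated at 100000 nM, between 30000 nM and 300000 nM.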

Compound 4, half-maximal cytotoxic concentration: > 100000 nM
Compound 4: only a limit was reported; the forecaster's own chance of this, stated with the estimate: 50%; the middle value lies on the limit itself.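

Putting (diisopropylamino)methyl in place of 3-bromophenyl on a saturated chain carbon bound to an aromatic nitrogen gives an at least 1.1-fold higher number from compound 3 to compound 4 (0.07 log units; that floor lies within the scatter) in this assay. This position therefore accepts a chain with no ring in place of an aromatic ring, with no readable loss of tolerance. The steps from compound 1 and from compound 2 to compound 4 cannot be read, because both ends of each are limits: the limit of > 100000 nM in this assay, at which 3 of the 4 values shown sit.

Going by these compounds, how far compound 4 lies past its limit stays open. So does whether a morpholine or a carboxylic acid at this place would give a readable number.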